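A few compounds are considered here, and "the series" means these few. Any claim that something is new, unique, unknown or untested is made for them only; others in the source may bear on it.

Compound 1 `Cc1ccccc1Oc1ccc(C#N)cc1S(=O)(=O)NC(=O)NC(C)C` is a sulfonylurea; in a functional assay on HEK293 cells for antagonist activity at thromboxane A2 receptor (Homo sapiens), read by fluorescence and calcium flux (on this read-out lower numbers stand for stronger inhibition and higher numbers for weaker inhibition), compound 1 gives 8680 nM. Compound 2 `Cc1ccccc1Oc1ccc(C#N)cc1S(=O)(=O)NC(=O)NC(C)(C)C` carries one more methyl, the change being (methyl in place of hydrogen on a saturated chain carbon bound to an amide-type nitrogen and two saturated chain carbons), and in this assay compound 2 gives 3690 nM, a step of a 2.4-fold lower number from compound 1 to compound 2 (0.37 log units; beyond the scatter). Compound 3 `CC(C)NC(=O)NS(=O)(=O)c1cc(C#N)ccc1Oc1ccc(F)cc1` shares the sulfonylurea of compound 1 but differs in its core by 4-fluorophenyl in place of 2-methylphenyl on an oxygen on an aromatic ring; in this assay compound 3 gives 9620 nM, a step of a 1.1-fold higher number from compound 1 to compound 3 (0.04 log units; within the scatter), so the two values cannot be told apart.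

Compound 4 `CC(C)(C)NC(=O)NS(=O)(=O)c1cc(C#N)ccc1Oc1ccc(F)cc1` is not yet measured. It stands to compound 3 as compound 2 stands to compound 1: the change is methyl in place of hydrogen on a saturated chain carbon bound to an amide-type nitrogen and two saturated chain carbons, made at a place described in the same words as before, so it is the same change set on a different core. For the measured compounds named here, only one earlier instance of this change is known, so the expectation rests on a single step. Compound 4 is expected to show a step of about a 2.4-fold lower number from compound 3 to compound 4 (0.38 log units; beyond the scatter) in this assay because compound 1 to compound 2 gave a 2.4-fold lower number from compound 1 to compound 2 (0.37 log units; beyond the scatter). Compound 4 is therefore estimated at 4000 nM, most likely between 2000 nM and 8000 nM.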

Compound 4, half-maximal inhibitory concentration: 4350 nM
Beside the measured number, compound 4's estimate is 1.1-fold (0.04 log units) below it; low and high end bracket the measured number.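

Swapping isopropyl for tert-butyl on the core of compound 3 gives a step of a 2.2-fold lower number from compound 3 to compound 4 (0.34 log units; beyond the scatter) in this assay, and this step matches the one seen on the core of compound 1: the same change on two cores in this assay, a 2.4-fold lower number (0.37 log units; beyond the scatter) from compound 1 to compound 2 and a 2.2-fold lower number (0.34 log units; beyond the scatter) from compound 3 to compound 4, 1.1-fold (0.03 log units) apart, within the scatter of two such steps

With tert-butyl in place, putting 4-fluorophenyl where 2-methylphenyl stood gives a step of a 1.2-fold higher number from compound 2 to compound 4 (0.07 log units; within the scatter), so these two values cannot be told apart, and the result agrees with the same swap made on the isopropyl compounds: the same change on two cores in this assay, a 1.1-fold higher number (0.04 log units; within the scatter) from compound 1 to compound 3 and a 1.2-fold higher number (0.07 log units; within the scatter) from compound 2 to compound 4, 1.1-fold (0.03 log units) apart, within the scatter of two such steps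

Across these four compounds, then, the tert-butyl step carried over from one core to the other with its size intact, but this rests on just two cores in a single assay and shows neither that it would hold on a further core nor why it occurs.

The compounds shown leave open whether the number would keep falling with another group on the amide-type nitrogen, such as cyclohexyl or a longer chain like n-butyl. They also leave open whether the step would survive with a different group on the oxygen, such as 4-methoxyphenyl.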